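The source may hold more compounds than are shown below. What is called first, only, known or untested is meant among the compounds shown, and "the series" means these compounds.

Measured compounds:
- compound 1 `CCC(C)n1ncn(-c2ccc(N3CCN(c4ccc(OC[C@@H]5CO[C@@](CN(C)C)(c6ccc(Cl)cc6Cl)O5)cc4)CC3)cc2)c1=O`: 1400 nM
- compound 2 `CCC(C)n1ncn(-c2ccc(N3CCN(c4ccc(OC[C@@H]5CO[C@@](CN6CCN(C)CC6)(c6ccc(Cl)cc6Cl)O5)cc4)CC3)cc2)c1=O`: 396 nM
- compound 3 `CCc1nccn1C[C@@]1(c2ccc(Cl)cc2Cl)OC[C@@H](COc2ccc(N3CCN(c4ccc(-n5cnn(C(C)CC)c5=O)cc4)CC3)cc2)O1`: 224 nM

In a functional assay on HUVEC cells (Homo sapiens), read by scintillation counting and thymidine incorporation, with a stated time of 24 h (a lower number here means a stronger inhibitor, a higher number a weaker inhibitor), compound 1 stands at the highest of the three numbers, that is, it is the weakest inhibitor of the set; its nearest neighbour is compound 2 and its furthest is compound 3. The shared core is kept throughout; the three compounds differ only in the group on a saturated chain carbon bound to a saturated ring carbon.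

Compound 4 `CCC(C)n1ncn(-c2ccc(N3CCN(c4ccc(OC[C@@H]5CO[C@@](Cn6nnnc6-c6ccccc6)(c6ccc(Cl)cc6Cl)O5)cc4)CC3)cc2)c1=O` is not yet measured. Against compound 1 it differs in one place: 5-phenyl-1H-tetrazol-1-yl in place of dimethylamino on a saturated chain carbon bound to a saturated ring carbon.

Among the compounds with values here, two measured steps bear on this change, since both also start from compound 1 and both exchange the dimethylamino group at the same place for a ring-bearing group: a 3.5-fold lower number from compound 1 to compound 2 (0.55 log units; beyond the scatter) and a 6.3-fold lower number from compound 1 to compound 3 (0.80 log units; beyond the scatter). Both steps go in the same direction and both lie beyond the scatter. The two ring-bearing groups themselves are not separated: a 1.8-fold lower number from compound 2 to compound 3 (0.25 log units; within the scatter).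

On that basis compound 4 is expected to give a lower number than compound 1 in this assay, with the step estimated as a 4.4-fold lower number from compound 1 to compound 4 (0.64 log units; beyond the scatter). The value for compound 4 is estimated at 320 nM, within a range from 110 nM to 1100 nM.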

Compound 4, half-maximal inhibitory concentration: 119 nM
Beside the measured number, compound 4's estimate is 2.7-fold (0.43 log units) above it; the measured number falls inside the stated range.
By their numbers in this assay, from the lowest: compounds 4, 3 and 2 (each within the scatter of the next, the first and the last beyond it); then compound 1.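

In this assay, within the data shown here, the exchange of dimethylamino for 5-phenyl-1H-tetrazol-1-yl on a saturated chain carbon bound to a saturated ring carbon gives a 12-fold lower number from compound 1 to compound 4 (1.07 log units; beyond the scatter), the first step at this place that is large. All three ring-bearing groups shown give a lower number than dimethylamino, and no compound in the set goes against this; the place therefore accepts a group with a five-membered aromatic ring bearing 4 hetero atoms and a six-membered aromatic ring of carbon only. The ring-bearing groups also begin to separate, with a 3.3-fold lower number from compound 2 to compound 4 (0.52 log units; beyond the scatter), whereas a 1.9-fold lower number from compound 3 to compound 4 (0.27 log units; within the scatter) leaves 5-phenyl-1H-tetrazol-1-yl and 2-ethyl-1H-imidazol-1-yl unresolved.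

Nothing shown accounts for the size of these steps.

The compounds shown do not tell whether the step belongs to the tetrazole ring or to its phenyl, since the set holds neither the unsubstituted 1H-tetrazol-1-yl nor a 5-methyl-1H-tetrazol-1-yl group. Also open, from the compounds shown here alone, is how a substituted phenyl, such as 4-chlorophenyl on the tetrazole, or a morpholin-4-yl group at the same place would read in this assay.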